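From an Iodophenyl Amide to a Chloro-fluoropyridyl Amide

The compounds below may be only part of what the source reports. "The series", "measured", "known", "first", "only" and "open" are said of these compounds alone.

Measured so far:
compound 1 `O=C(Nc1ccc(S(=O)(=O)Nc2ccccc2)cc1)c1ccc(I)cc1F` — 36%
compound 2 `O=C(NS(=O)(=O)c1ccc(NC(=O)c2ccc(Cl)cc2Cl)cc1)c1ccccc1` — "not determined" (no result reported)

Among the compounds with values here, compound 1 is the only compound with a number in a functional assay on HEK293 cells for agonist activity at probable G-protein coupled receptor 27 (Homo sapiens), read by a luciferase reporter and beta-arrestin recruitment, with a stated time of 10 min; on this read-out higher numbers stand for larger maximal responses and lower numbers for smaller maximal responses; in that assay compound 1 reaches 36%. Compound 2 was also tested, but in this assay compound 2 shows "not determined" (no result reported), so compound 1 stands alone on the numbers shown and no step between measured compounds can be read off. Compound 3 `O=C(Nc1ccc(S(=O)(=O)Nc2ccccc2)cc1)c1ccc(Cl)nc1F` differs from compound 1 at a single place: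

6-chloro-2-fluoropyridin-3-yl in place of 2-fluoro-4-iodophenyl on a carbonyl carbon

Within the data shown here, with no measured step to lean on, the account can only set an expectation. The step from compound 1 to compound 3 is expected to stay small, likely within the usual scatter or slightly downward: a number 6 percentage points lower from compound 1 to compound 3 (within the scatter). Compound 3 is accordingly estimated at 30% in this assay, with a range from 10% to 55%.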

Compound 3, largest response reached (Emax), in percent of the reference or control that the assay uses: 78%
Beside the measured number, compound 3's estimate is 48 percentage points below it, and the stated range ends below it.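

In this assay, the group on the carbonyl carbon emerges as a place where a single change can move the maximal response well beyond the usual scatter: 6-chloro-2-fluoropyridin-3-yl in place of 2-fluoro-4-iodophenyl gives a number 42 percentage points higher from compound 1 to compound 3 (beyond the scatter) on the otherwise unchanged core. The two groups have the same count of heavy atoms and both carry fluorine, so the step exchanges iodine for chlorine and brings in a ring nitrogen that counts as a hydrogen-bond acceptor. No measurement shown explains why the response changes at this position.

The compounds shown leave open whether the larger response follows the ring nitrogen or the chlorine, as both change in this one step. Also open, from the compounds shown here alone, is whether an amine or a methoxy group in place of that chlorine would keep the response of compound 3.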